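Thiocarbonyl-linked replacement for a benzyl group on an inactive core

The compounds below may be only part of what the source reports. "The series", "measured", "known", "first", "only" and "open" are said of these compounds alone.

Measured so far:
compound 1, `NC(=O)c1c(NC(=O)c2ccccc2Cl)sc2c1CCN(Cc1ccccc1F)C2`, > 50000 nM
compound 2, `NC(=O)c1c(NC(=O)c2ccc(C(F)(F)F)cc2)sc2c1CCN(Cc1ccccc1F)C2`, > 50000 nM

In a functional assay on HeLa cells (Homo sapiens) for antiproliferative activity, with a stated time of 24 h (a lower number here means a stronger inhibitor, a higher number a weaker inhibitor), compound 1 gives > 50000 nM, which is a limit of the assay and not a number. Compound 2 likewise gives > 50000 nM in this assay, again a limit. Among the measured compounds shown here, the one step between them, a step that the two limits leave unreadable from compound 1 to compound 2, therefore cannot be read, and compound 1 stands only at a limit, with both values resting on (the limit of > 50000 nM in this assay, at which 2 of the 2 values shown sit).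

Compound 3, `NC(=O)c1c(NC(=O)c2ccccc2Cl)sc2c1CCN(C(=S)Nc1ccccc1F)C2`, is not yet measured. It differs from compound 1 in this way: a group of 10 heavy atoms (7 carbon, 1 nitrogen, 1 fluorine, 1 sulfur; one six-membered aromatic ring of carbon only) in place of a group of 8 heavy atoms (7 carbon, 1 fluorine; one six-membered aromatic ring of carbon only), on an amine nitrogen in a ring. For the measured compounds named here, no measured step bears on this change; the only step known is unreadable from its two limits, so nothing in the numbers points to either direction or to any size of step.

With compound 1 standing only at a limit, compound 3 is expected to give 60000 nM, between 15000 nM and 250000 nM, a step that the limit leaves unreadable from compound 1 to compound 3 that is an expectation and not a measurement.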

Compound 3, half-maximal inhibitory concentration: 28700 nM
Compound 3: the middle estimate sits 2.1-fold (0.32 log units) above what was measured, and the stated range covers the measured number.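

In this assay, compound 3 is the only one of the three compounds shown to give a number and not a limit, so this place, the amine nitrogen in the ring, is one where a change in the group can be read on the shared core. Putting the thiocarbonyl-linked group in place of 2-fluorobenzyl gives an at least 1.7-fold lower number from compound 1 to compound 3 (0.24 log units; that floor lies within the scatter), so the direction is visible, though the size of the step is known only as a floor. The earlier step, on the carbonyl carbon, could not show this, and it cannot be read: the limit of > 50000 nM in this assay, at which 2 of the 3 values shown sit.

The compounds shown leave open whether the step comes from the sulfur, the added nitrogen or the fluorinated ring. They also leave open whether a urea carbonyl in place of the thiocarbonyl, or a morpholine on the same nitrogen, would give a number at all.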